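A few compounds are considered here, and "the series" means these few. Any claim that something is new, unique, unknown or untested is made for them only; others in the source may bear on it.

Compound 2 `O=C(Nc1cc2c(Nc3ccc(F)c(Cl)c3)ncnc2cc1O[C@H]1CCOC1)N1CCC(N2CCCC2)CC1` gives 317 nM in a functional assay on A-431 cells (Homo sapiens) for antiproliferative activity, read by sulforhodamine B assay, with a stated time of 72 h (on this read-out lower numbers stand for stronger inhibition and higher numbers for weaker inhibition), and stands at the low end of the two numbers to hand, with compound 1 `CN(C)CCN(C)C(=O)Nc1cc2c(Nc3ccc(F)c(Cl)c3)ncnc2cc1O[C@H]1CCOC1` at 450 nM in this assay within the scatter of it. Compound 3 `O=C(Nc1cc2c(Nc3ccc(F)c(Cl)c3)ncnc2cc1O[C@H]1CCOC1)N1CCC(CCO)CC1` carries 2-hydroxyethyl in place of pyrrolidin-1-yl on a saturated ring carbon. Among the compounds with values here, the only measured step, a 1.4-fold lower number from compound 1 to compound 2 (0.15 log units; within the scatter), exchanged the group on the carbonyl carbon and stayed within the scatter; no measured step touches the saturated ring carbon that compound 3 alters. The step for compound 3 is therefore expected to be a 1.3-fold higher number from compound 2 to compound 3 (0.10 log units; within the scatter), a change that is not expected to reach beyond the scatter. Compound 3 is estimated at 400 nM, in a range from 150 nM to 1100 nM.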

Compound 3, half-maximal inhibitory concentration: 759 nM
Compound 3: the middle estimate sits 1.9-fold (0.28 log units) below what was measured; the range from low to high includes it.
By their numbers in this assay, from the lowest: compounds 2, 1 and 3 (each within the scatter of the next, the first and the last beyond it).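

Within the data shown here, at the saturated ring carbon, three ring bonds from the ring nitrogen, 2-hydroxyethyl in place of pyrrolidin-1-yl is the first change in this assay to pass the scatter, with a 2.4-fold higher number from compound 2 to compound 3 (0.38 log units; beyond the scatter). Exchanging the whole group on the carbonyl carbon, 4-(2-hydroxyethyl)piperidin-1-yl for (2-(dimethylamino)ethyl)(methyl)amino, gives a 1.7-fold higher number from compound 1 to compound 3 (0.23 log units; within the scatter), which remains within the scatter. Nothing available explains the step at the ring carbon. Open, on these data alone, is how a dimethylamino group or a longer hydroxyalkyl chain on this ring carbon would read, and so whether leaving pyrrolidin-1-yl or entering 2-hydroxyethyl sets the step.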